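Ether in place of cyclohexyl on the ring amine

This account rests on a few compounds, and the source may have more. Where it says the series, first, only, none or still open, it means among the compounds named here.

Compound 1 `COc1cccc(-n2cc3nc(-c4cccnc4C)n(C[C@H]4CCCN(CC5CCCCC5)C4)c(=O)c3n2)c1`: 200 nM
Compound 2 `Cc1ncccc1-c1nc2cn(-c3cccc(OC(C)C)c3)nc2c(=O)n1C[C@H]1CCCN(C[C@H]2CCCO2)C1`: 11 nM

In an assay on HEK293 cells for displacement of a labelled ligand from growth hormone secretagogue receptor type 1 (Homo sapiens), with a stated time of 60 min (on this read-out higher numbers stand for weaker inhibition and lower numbers for stronger inhibition), compound 1 gives 200 nM, the higher of the two numbers. Compound 2, which is not a single-point change from it, gives 11 nM, a gap beyond the scatter. Compound 3 `CCO[C@@H](C)CN1CCC[C@H](Cn2c(-c3cccnc3C)nc3cn(-c4cccc(OC)c4)nc3c2=O)C1` is not yet measured. It differs from compound 1 by 1-ethoxyethyl in place of cyclohexyl on a saturated chain carbon bound to an amine nitrogen in a ring. Because compound 2 gives 11 nM while carrying an oxygen-bearing chain on the same amine, a step downward beyond the scatter is expected from compound 1 to compound 3, namely a 5.7-fold lower number from compound 1 to compound 3 (0.76 log units; beyond the scatter). Compound 3 is estimated at 35 nM, within 9 nM to 140 nM.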

Compound 3, half-maximal inhibitory concentration: 5 nM
Beside the measured number, compound 3's estimate is 7.0-fold (0.85 log units) above it; the measured number lies below the stated range.
By their numbers in this assay, from the lowest: compound 3; then compound 2; then compound 1.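

In this assay, 1-ethoxyethyl in place of cyclohexyl on a saturated chain carbon bound to an amine nitrogen in a ring gives a 40-fold lower number from compound 1 to compound 3 (1.60 log units; beyond the scatter). Going by these compounds alone, this is the first comparison at this position in which only one place changes, and it shows that the carbon-only ring can give way to an open chain bearing one oxygen with a large gain in inhibition. No measurement shown here accounts for the size of this step.

On these data alone, whether the step follows from the oxygen or from the loss of the ring stays open, and a pentyl chain in the same place would separate the two. The opposite configuration at the stereocentre of the 1-ethoxyethyl group is also an open question.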